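Methyl for Methoxy on the Benzamide of Compound 3

A few compounds are considered here, and "the series" means these few. Any claim that something is new, unique, unknown or untested is made for them only; others in the source may bear on it.

Measured compounds:
compound 1 `Nc1nccn2cc(-c3ccccc3)nc12`: 30%
compound 2 `O=C(Nc1nccn2cc(-c3ccccc3)nc12)c1ccccc1`: 18%
compound 3 `COc1ccc(C(=O)Nc2nccn3cc(-c4ccccc4)nc23)cc1`: 1%

In an assay on cells for displacement of a labelled ligand from adenosine receptor A1 (Homo sapiens), read by scintillation counting, with a stated time of 120 min, tested at 1 uM (on this read-out higher numbers stand for more inhibition at the one concentration tested (going by the name of the read-out) and lower numbers for less inhibition), compound 3 stands lowest of the three numbers; compound 2 lies nearest, and compound 1 furthest, both beyond the scatter above it. Compound 4 `Cc1ccc(C(=O)Nc2nccn3cc(-c4ccccc4)nc23)cc1` differs from compound 3 by methyl in place of methoxy on an aromatic carbon. For the measured compounds named here, no measured step swaps these two groups directly. The nearest comparison is a number 17 percentage points lower from compound 2 to compound 3 (beyond the scatter), which marks the arrival of the methoxy group; a number 12 percentage points lower from compound 1 to compound 2 (beyond the scatter) concerns the benzoyl group and bears less on this change. A methyl analogue is expected to fall between compound 3 and compound 2, giving a modest rise a number 7 percentage points higher from compound 3 to compound 4 (within the scatter). Compound 4 is therefore estimated at 8%, within 0% to 22%.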

Compound 4, a percentage reported as inhibition, at one concentration (the size of the read-out at that concentration, not a potency): 26%
The estimate for compound 4 lay 18 percentage points below the measured number, outside the stated range (above it).
By their numbers in this assay, from the lowest: compound 3; then compounds 2, 4 and 1 (each within the scatter of the next, the first and the last beyond it).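

Replacing 4-methoxyphenyl with 4-methylphenyl gives a number 25 percentage points higher from compound 3 to compound 4 (beyond the scatter) in this assay, so the read-out at this position depends on which group is present. Methyl in place of hydrogen gives a number 8 percentage points higher from compound 2 to compound 4 (within the scatter), so the fall seen with methoxy does not recur with methyl. Nothing available explains the difference between the two groups. Open, on these data alone, is how an amine, a chlorine or a longer chain such as ethyl would read at this position. Also open, as far as these compounds go, is whether methyl would give the same result on the other carbons of this ring.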